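A few compounds are considered here, and "the series" means these few. Any claim that something is new, unique, unknown or untested is made for them only; others in the source may bear on it.

Compounds measured so far:
compound 1 `CC(C)(C)C1=NN(c2ccc(C(=O)O)cc2)C(c2ccc(O)cc2)C1` — in an assay on U-937 cells for inhibition of protein kinase C zeta type (Homo sapiens), read by reporter gene assay (on this read-out lower numbers stand for stronger inhibition and higher numbers for weaker inhibition), compound 1 gives "not determined" (no result reported)
compound 2 `CC(C)(C)C1=NN(c2cccc(C(F)(F)F)c2)C(c2ccc(O)cc2)C1` — 2700 nM
compound 3 `Cc1cccc(N2N=C(C(C)(C)C)CC2c2ccc(O)cc2)c1` — in this assay compound 3 gives "not determined" (no result reported)

Compound 3 carries a 3-methylphenyl group on the ring nitrogen of the shared core and stands nowhere on the numbers: no result is reported for it, as is also the case for compound 1. Of the three measured compounds only compound 2 returns a figure, and in this assay compound 2 gives 2700 nM. For the measured compounds named here, no step between measured compounds that differ in one place is available, so nothing is known about how a change on the ring nitrogen moves the read-out.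

Compound 4 `CC(C)(C)C1=NN(c2ccc(F)c(Cl)c2)C(c2ccc(O)cc2)C1` is the next candidate. It differs from compound 3 by 3-chloro-4-fluorophenyl in place of 3-methylphenyl on an amine nitrogen in a ring. Going by the values given here, since compound 3 has no number, no step can be computed for this pair and the direction of the change cannot be read from the data. Among the compounds with values here, the only anchor is compound 2, which carries a different substituted phenyl on the same ring nitrogen. The size of the step from compound 3 to compound 4 in this assay is therefore unknown; no claim is made that it lies beyond the scatter in either direction.

Within the data shown here, on the single anchor of compound 2, compound 4 is expected to give about 3000 nM in this assay, with a range from 800 nM to 12000 nM.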

Compound 4, half-maximal inhibitory concentration: 1900 nM
Compound 4: the middle estimate sits 1.6-fold (0.20 log units) above what was measured; the range from low to high includes it.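

No new step can be read for compound 4: compound 3, which differs from it in one place, has no reported number. No available evidence bears on this result. The compounds shown leave open how exchanging 3-methylphenyl for 3-chloro-4-fluorophenyl on the amine nitrogen in a ring moves the read-out.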